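Rearranging Two Fluorines on an Aromatic Ring

The compounds below may be only part of what the source reports. "The series", "measured", "known", "first", "only" and "open" are said of these compounds alone.

Three compounds share one core and differ only in the group attached to the amine nitrogen in a ring. Compound 1 `Nc1scc(CN2CCN(c3ccc([N+](=O)[O-])cc3)CC2)c1C(=O)c1ccc(Cl)cc1` carries a 4-nitrophenyl there; in an assay on CHO cells for displacement of a labelled ligand from adenosine receptor A3 (Homo sapiens), read by scintillation counting, with a stated time of 120 min, tested at 10 uM (a higher number here means more inhibition at the concentration tested (going by the name of the read-out), a lower number less inhibition), compound 1 gives 2%. Compound 2 `Nc1scc(CN2CCN(c3ccc(OC(F)(F)F)cc3)CC2)c1C(=O)c1ccc(Cl)cc1` carries a 4-(trifluoromethoxy)phenyl, and in this assay compound 2 gives 1%. Compound 3 `Nc1scc(CN2CCN(c3c(F)cccc3F)CC2)c1C(=O)c1ccc(Cl)cc1` carries a 2,6-difluorophenyl; in this assay compound 3 gives 4%, the largest of the three numbers, yet all three sit within the scatter of one another: a number 1 percentage points lower from compound 1 to compound 2 (within the scatter), a number 2 percentage points higher from compound 1 to compound 3 (within the scatter) and a number 3 percentage points higher from compound 2 to compound 3 (within the scatter). At the tested concentration, none shows meaningful inhibition.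

Compound 4 `Nc1scc(CN2CCN(c3cccc(F)c3F)CC2)c1C(=O)c1ccc(Cl)cc1` is the next step: 2,3-difluorophenyl in place of 2,6-difluorophenyl on an amine nitrogen in a ring. The measured steps that bear on this are the two leading to compound 3, each of which also exchanged the group on the ring nitrogen, and neither moved the read-out beyond the scatter. Compound 4 is therefore expected to stay flat and near zero, with a number 1 percentage points lower from compound 3 to compound 4 (within the scatter). The estimate for compound 4 is 3%, with a range from -5% to 12%.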

Compound 4, a percentage reported as inhibition, at one concentration (the size of the read-out at that concentration, not a potency): 0%
For compound 4 the middle estimate is 3 percentage points above the measured one; the measured number falls inside the stated range.
By their numbers in this assay, from the lowest: compounds 4, 2, 1 and 3 (each within the scatter of the next).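

The two fluorines of compound 3 and compound 4 are the same atoms joined differently, and this rearrangement alone is a step that stays within the scatter in this assay: a number 4 percentage points lower from compound 3 to compound 4 (within the scatter). Compound 4 also cannot be separated from the two para-free comparison groups: a number 1 percentage points lower from compound 2 to compound 4 (within the scatter) and a number 2 percentage points lower from compound 1 to compound 4 (within the scatter). Across these four compounds, then, neither the placement of the two fluorines nor the exchange of the whole group on the amine nitrogen in a ring gives a readable difference, and nothing available explains this flat result.

Going by these compounds, all four compounds carry a substituted phenyl at this position, so it remains open whether an unsubstituted phenyl, a benzyl or a cyclohexyl there would give a readable inhibition. Changes elsewhere on the shared core, such as replacing the chlorine with a methoxy group, also remain open.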